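The source may hold more compounds than are shown below. What is called first, only, known or untested is meant among the compounds shown, and "the series" means these compounds.

Working notes on the series in an assay on isolated protein for binding affinity to Equilibrative nucleoside transporter 1 (Homo sapiens); a lower number here means a stronger inhibitor, a higher number a weaker inhibitor.

Compound 2 `O=[N+]([O-])c1ccc(CNc2ncnc3c2ncn3[C@@H]2O[C@H](CO)C[C@H]2O)cc1` gives 977 nM in this assay. Of the two measured compounds it holds the highest number; its nearest neighbour, compound 1 `O=[N+]([O-])c1ccc(CNc2ncnc3c2ncn3[C@@H]2O[C@H](CO)[C@@H](O)[C@H]2O)c(Cl)c1`, gives 347 nM in this assay, a gap that lies beyond the usual scatter. Within the data shown here, compound 1 and compound 2 differ in more than one place at once, so the two values show only that compound 2 sits at the weaker end of this small set and nothing about which change carries the gap.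

Compound 3 `C[C@H]1O[C@@H](n2cnc3c(NCc4ccc([N+](=O)[O-])cc4)ncnc32)[C@H](O)[C@@H]1O` is the next member and has not yet been measured in this assay. Relative to compound 2 the change is 3,4-dihydroxy-5-methyloxolan-2-yl in place of 3-hydroxy-5-(hydroxymethyl)oxolan-2-yl on an aromatic nitrogen; both oxolane groups carry the same number of donors and acceptors, so the difference lies in where the hydroxyl and methyl groups sit on the five-membered ring.

Among the measured compounds shown here, no measured step isolates this change. The expectation for compound 3 is a modest shift toward a lower number in this assay, of the size a 2.0-fold lower number from compound 2 to compound 3 (0.29 log units; within the scatter), not secured beyond the scatter. The estimated value for compound 3 in this assay is 500 nM, with a range from 150 nM to 2000 nM.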

Compound 3, half-maximal inhibitory concentration: 21.9 nM
Compound 3: middle estimate off by 23-fold (1.36 log units), on the high side; measured number below the stated range.
By their numbers in this assay, from the lowest: compound 3; then compound 1; then compound 2.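

In this assay, the sugar-like group on the aromatic nitrogen proves highly sensitive to how it is arranged: 3,4-dihydroxy-5-methyloxolan-2-yl in place of 3-hydroxy-5-(hydroxymethyl)oxolan-2-yl gives a 45-fold lower number from compound 2 to compound 3 (1.65 log units; beyond the scatter), a large step beyond the scatter. The two groups match in heavy atoms, hydrogen-bond donors and hydrogen-bond acceptors, so this step comes with a rearrangement of the same atoms on the five-membered ring, together with a rise from 3 to 4 defined stereocentres, and not with any change in those counts. No measurement bears on the reason for the size of this step.

The step combines two changes, a hydroxymethyl replaced by methyl and a second ring hydroxyl gained, and the compounds shown do not separate their contributions. Going by these compounds, it also remains open whether the methyl can give way to an ethyl group or an aminomethyl group, or the second ring hydroxyl to an amine, while keeping the number in this assay at the level of compound 3 at 21.9 nM.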